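Hydroxamate chain length on a propargylamine aniline scaffold

The compounds below may be only part of what the source reports. "The series", "measured", "known", "first", "only" and "open" are said of these compounds alone.

Measured so far:
compound 1 `C#CCN(C)Cc1cccc(NC(=O)CCCCCCCC(=O)NO)c1` gives 3780 nM
compound 2 `C#CCN(C)Cc1cccc(NC(=O)CCCCCCCCC(=O)NO)c1` gives 2940 nM
compound 3 `C#CCN(C)Cc1ccc(NC(=O)CCCCC(=O)NO)cc1` gives > 10000 nM

The three measured compounds were run in a functional assay on DU-145 cells (Homo sapiens) for inhibition, read by MTT assay, with a stated time of 48 h; a higher number here means a weaker inhibitor of growth, a lower number a stronger inhibitor of growth. Compound 1 and compound 2 share a core and differ by (hydroxycarbamoyl)methyl in place of hydroxycarbamoyl on a saturated chain carbon, seven bonds along the chain from a carbonyl carbon. The step of a 1.3-fold lower number from compound 1 to compound 2 (0.11 log units; within the scatter) is within the scatter, so the two values are read as equivalent. For compound 3 this assay returns only a limit, > 10000 nM; this is the limit noted as the limit of > 10000 nM in this assay, at which 1 of the 3 values shown sits. How the core of compound 3 differs from the core of compound 1 is not broken down here.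

Compound 4 `C#CCN(C)Cc1ccc(NC(=O)CCCCCC(=O)NO)cc1` is not yet measured. It differs from compound 3 by (hydroxycarbamoyl)methyl in place of hydroxycarbamoyl on a saturated chain carbon, four bonds along the chain from a carbonyl carbon. Within the data shown here, this is the same kind of change as the one from compound 1 to compound 2, but not the same: there it sits seven bonds along the chain from a carbonyl carbon, here four bonds along the chain from a carbonyl carbon. Among the measured compounds shown here, since the one measured step of this kind, a 1.3-fold lower number from compound 1 to compound 2 (0.11 log units; within the scatter), stayed within the scatter, the step from compound 3 to compound 4 is expected to be small as well, a step that the limit leaves unreadable from compound 3 to compound 4. Compound 4 is therefore expected to give about 12000 nM in this assay, with a range from 4000 nM to 40000 nM, and a real chance that only a limit is reported again.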

Compound 4, concentration for 50% growth inhibition: > 10000 nM
Compound 4 was reported as a limit; the forecaster's own chance of this, stated with the estimate: 55%; the middle value does not contradict the limit.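

In this assay compound 4 gives > 10000 nM as a limit of the assay, not a number. Compound 3 is likewise reported only as a limit, and no step between compound 3 and compound 4 can be read: the limit of > 10000 nM in this assay, at which 2 of the 4 values shown sit.

The compounds shown leave open where the true values of compound 3 and compound 4 lie, and whether (hydroxycarbamoyl)methyl in place of hydroxycarbamoyl changes growth inhibition on this core.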